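The compounds below may be only part of what the source reports. "The series", "measured", "known", "first", "only" and "open" are said of these compounds alone.

Compound 2 `COc1ccc(CN(C(=O)C(C)C)c2cc(OC)c(OC)c(OC)c2)cc1O` gives 310 nM in a functional assay on HCT-116 cells (Homo sapiens) for inhibition, read by MTT assay, with a stated time of 48 h (on this read-out higher numbers stand for weaker inhibition and lower numbers for stronger inhibition), the highest of the two numbers measured, and therefore the weaker of the pair. Among the compounds with values here, compound 1 `CCC/C=C/C(=O)N(Cc1ccc(OC)c(O)c1)c1cc(OC)c(OC)c(OC)c1` gives 95 nM in this assay, and the one step between them, a 3.3-fold higher number from compound 1 to compound 2 (0.51 log units; beyond the scatter), bears directly on what follows. Compound 3 `C=CC(=O)N(Cc1ccc(OC)c(O)c1)c1cc(OC)c(OC)c(OC)c1` carries the change (vinyl in place of isopropyl on a carbonyl carbon), which again brings a double bond back onto the carbonyl carbon. Since that earlier step weakened inhibition when the double bond was removed, compound 3 is expected to move back the other way, by a 2.1-fold lower number from compound 2 to compound 3 (0.32 log units; beyond the scatter). The estimate for compound 3 is 150 nM, in a range from 60 nM to 400 nM.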

Compound 3, half-maximal inhibitory concentration: 98 nM
Compound 3: middle estimate off by 1.5-fold (0.18 log units), on the high side, within the range that was stated.
By their numbers in this assay, from the lowest: compounds 1 and 3 (each within the scatter of the next); then compound 2.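

In this assay, vinyl in place of isopropyl on the carbonyl carbon gives a 3.2-fold lower number from compound 2 to compound 3 (0.50 log units; beyond the scatter). The longer pent-1-en-1-yl chain offers no measurable gain over vinyl, with a 1.0-fold higher number from compound 1 to compound 3 (0.01 log units; within the scatter). Both compounds with a double bond at this place therefore sit within the scatter of each other, and no evidence is available to explain the pattern. Still open, going by these compounds, is whether the double bond itself matters, as isopropyl also differs from vinyl by being branched. An ethyl group or a saturated pentyl chain at this place would separate these two features.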